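This account rests on a few compounds, and the source may have more. Where it says the series, first, only, none or still open, it means among the compounds named here.

Compound 1, `COc1ccc2c(/C=C(\C#N)C(=O)c3c[nH]c4cc(F)ccc34)c[nH]c2c1`, gives in a functional assay on MIA PaCa-2 cells (Homo sapiens) for cytotoxicity, read by WST assay, with a stated time of 48 h (on this read-out higher numbers stand for weaker inhibition and lower numbers for stronger inhibition), only a limit of the assay, > 50000 nM.
Compound 2, `N#C/C(=C\c1c[nH]c2cc(F)ccc12)C(=O)c1c[nH]c2cc(F)ccc12`, gives in this assay only a limit of the assay, > 50000 nM.
Compound 3, `COc1ccc2[nH]cc(/C=C(\C#N)C(=O)c3c[nH]c4cc(F)ccc34)c2c1`, gives in this assay only a limit of the assay, > 50000 nM.

All three measured compounds therefore sit at the same point, (the limit of > 50000 nM in this assay, at which 3 of the 3 values shown sit), and none of them has a numeric potency to compare. Compound 1 arises from compound 2 through one change, (methoxy in place of fluoro on an aromatic carbon). The size of the step that the two limits leave unreadable from compound 2 to compound 1 cannot be read, since both ends are limits rather than numbers. Compound 3 and compound 2 share a part but differ in their cores, and the difference between the two cores is not broken down here.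

Compound 4, `COc1ccc2c(C(=O)/C(C#N)=C/c3c[nH]c4ccc(OC)cc34)c[nH]c2c1`, is not yet measured. Among the compounds with values here, it arises from compound 3 through (methoxy in place of fluoro on an aromatic carbon), which is the same change, at the same kind of place, as the one from compound 2 to compound 1.

The expectation for compound 4 in this assay is that it, too, will come back only as a limit. This rests on compound 1, which after the same change still showed only a limit, > 50000 nM. The step that the limit leaves unreadable from compound 3 to compound 4 is accordingly expected to be unreadable or near zero. The estimate for compound 4 is 70000 nM, within 25000 nM to 200000 nM.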

Compound 4, half-maximal inhibitory concentration: > 50000 nM
Compound 4 gave a limit, no number; the forecaster's own chance of this, stated with the estimate: 85%; the middle value lies beyond the limit too.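

Compound 3 and compound 4 both give only a limit of the assay, not a number, so swapping fluoro for methoxy between them yields no step that can be read: the limit of > 50000 nM in this assay, at which 4 of the 4 values shown sit.

The compounds shown leave open whether methoxy and fluoro differ at all in their effect in this assay, and what kind of structure related to these compounds would give a numeric potency there.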